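Taking a methoxy group off compound 3

The source may report more compounds than this note shows. Statements on the series, on what has been measured and on what is new or still open speak of the compounds shown alone.

In a functional assay on A549 cells (Homo sapiens) for cytotoxicity, read by MTT assay, with a stated time of 72 h (a higher number here means a weaker inhibitor, a lower number a stronger inhibitor), compound 1 (`O=C1/C(=C/c2ccccc2)COC/C1=C\c1ccccc1F`) gives 17600 nM, compound 2 (`O=C1/C(=C/c2cccc(O)c2)COC/C1=C\c1ccccc1F`) gives 7400 nM and compound 3 (`COc1ccc(OC)c(/C=C2\COC/C(=C\c3ccccc3F)C2=O)c1`) gives 8700 nM. Compound 3 thus lies within the scatter of compound 2, while compound 1 has a higher number than either, beyond the scatter.

Compound 4 (`COc1ccccc1/C=C1\COC/C(=C\c2ccccc2F)C1=O`) differs from compound 3 in one place, (hydrogen in place of methoxy on an aromatic carbon). This is hydrogen in place of methoxy on an aromatic carbon, meta to a large group and para to a methoxy group.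

Among the compounds with values here, only one measured step bears on this change: a 2.4-fold lower number from compound 1 to compound 2 (0.38 log units; beyond the scatter), a modest step that came with hydroxy in place of hydrogen on an aromatic carbon. That step involves a different group, and in it a group arrives, whereas here one leaves, so it is only a loose guide. Read in reverse, it points towards a higher number, in the direction of compound 1, but probably by less than that step. The expected change is a 1.3-fold higher number from compound 3 to compound 4 (0.10 log units; within the scatter), a small rise that may well stay within the scatter. For compound 4 the estimated value in this assay is 11000 nM, with an expected range of 5500 nM to 22000 nM.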

Compound 4, half-maximal inhibitory concentration: 5900 nM
For compound 4 the middle estimate is 1.9-fold (0.27 log units) above the measured one; measured number inside the range.
By their numbers in this assay, from the lowest: compounds 4, 2 and 3 (each within the scatter of the next); then compound 1.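

Taking away the methoxy group that sits meta to a large group and para to a methoxy group gives a 1.5-fold lower number from compound 3 to compound 4 (0.17 log units; within the scatter) in this assay, so this position can lose that group with no change that this assay can separate from the scatter. The methoxy group that remains is the part of the substitution that comes with a step beyond the scatter: a 3.0-fold lower number from compound 1 to compound 4 (0.47 log units; beyond the scatter) is a modest step, and it shows that a single methoxy group is enough to reach this level, with no need for the second one. Compound 4 also cannot be told apart from the hydroxy compound, as a 1.3-fold lower number from compound 2 to compound 4 (0.10 log units; within the scatter) stays within the scatter, so 2-methoxyphenyl in place of 3-hydroxyphenyl makes no measurable difference here.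

No independent measurement is available to explain any of these steps. On these data alone, it remains open whether a larger or differently built substituent at this position, such as an ethoxy group, an amine or a carboxylic acid, would also leave the number within the scatter of compound 3 or would move it clearly in either direction.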